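This account rests on a few compounds, and the source may have more. Where it says the series, first, only, none or still open, it means among the compounds named here.

Measured compounds in a functional assay on LoVo cells (Homo sapiens) for antiproliferative activity, read by MTT assay, with a stated time of 72 h; on this read-out lower numbers stand for stronger inhibition and higher numbers for weaker inhibition:
- compound 1, `Cn1cc(Nc2nn(Cc3ccc(C(=O)NC4CCCCC4)cc3)c(=O)c3ccccc23)cn1`: 5300 nM
- compound 2, `Cc1noc(C)c1-c1nn(Cc2ccc(C(=O)NC3CC3)cc2)c(=O)c2ccccc12`: > 100000 nM
- compound 3, `Cn1cc(-c2nn(Cc3ccc(C(=O)N4CCCCC4)cc3)c(=O)c3ccccc23)cn1`: 77100 nM

Compound 1 gives 5300 nM in this assay. Compound 3 gives 77100 nM in this assay. For compound 2 the read-out is a limit of the assay, not a number: compound 2 is recorded as > 100000 nM, which is the limit of > 100000 nM in this assay, at which 1 of the 3 values shown sits. Among the measured compounds shown here, compound 2 therefore stands at the edge of what the assay reports, and no step between measured compounds is available to calibrate any change from it.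

Compound 4, `Cc1noc(C)c1-c1nn(Cc2ccc(C(=O)NC3CCN(C)CC3)cc2)c(=O)c2ccccc12`, is the unmeasured member of the set. It differs from compound 2 in one place:
1-methylpiperidin-4-yl in place of cyclopropyl on an amide-type nitrogen

With compound 2 at a limit, the step to compound 4 cannot be placed against a measured neighbour. Compound 2 is recorded only as the limit > 100000 nM in this assay. The expected step from that point is an at least 1.6-fold lower number from compound 2 to compound 4 (0.22 log units; that floor lies within the scatter), and it may well remain within the scatter. Compound 4 is estimated at 60000 nM in this assay, with a range from 15000 nM to 200000 nM.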

Compound 4, half-maximal inhibitory concentration: > 100000 nM
Compound 4 gave a limit, no number; the forecaster's own chance of this, stated with the estimate: 40%; middle value at least 1.6-fold (0.22 log units) from the limit.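

In this assay, compound 2 and compound 4 are both recorded only as limits, so no step can be read between them: the limit of > 100000 nM in this assay, at which 2 of the 4 values shown sit.

The compounds shown leave open whether 1-methylpiperidin-4-yl in place of cyclopropyl on an amide-type nitrogen changes the read-out at all in this assay.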